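Swapping thiophen-3-yl for pyridin-3-yl in compound 3

The source may report more compounds than this note shows. Statements on the series, on what has been measured and on what is new or still open speak of the compounds shown alone.

Among the measured compounds shown here, in a functional assay on T47D cells (Homo sapiens) for cytotoxicity, read by CCK-8 assay (on this read-out lower numbers stand for stronger inhibition and higher numbers for weaker inhibition), compound 3 `Oc1ccc(-c2cc(-c3ccsc3)cc(-c3cccc(O)c3)n2)cc1` gives 760 nM, the only actual number in this small set. Compound 1 `Oc1cccc(-c2cc(-c3ccsc3)cc(-c3ccccc3O)n2)c1` gives only a limit, > 50000 nM. Compound 2 `Oc1ccc(-c2cc(-c3ccsc3)cc(-c3ccccc3O)n2)cc1` also gives only a limit, > 50000 nM. Both carry the same thiophen-3-yl group as the third compound and differ from it only in their hydroxyphenyl groups. Those changes produce large steps, an at least 65-fold lower number from compound 1 to compound 3 (1.81 log units; beyond the scatter) and an at least 65-fold lower number from compound 2 to compound 3 (1.81 log units; beyond the scatter), while the step that the two limits leave unreadable from compound 1 to compound 2 cannot be read.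

Compound 4 `Oc1ccc(-c2cc(-c3cccnc3)cc(-c3cccc(O)c3)n2)cc1` keeps the hydroxyphenyl groups of compound 3 and has pyridin-3-yl in place of thiophen-3-yl, on an aromatic carbon opposite the ring nitrogen (pyridin-3-yl in place of thiophen-3-yl on an aromatic carbon). For the measured compounds named here, no measured step changes this position, so the large steps give no direct measure of the swap. Compound 4 does retain the hydroxyphenyl pattern reached in the step of an at least 65-fold lower number from compound 2 to compound 3 (1.81 log units; beyond the scatter), so a real number rather than a limit is expected. In this assay the expected step is small and leans toward a higher number, a 1.7-fold higher number from compound 3 to compound 4 (0.23 log units; within the scatter), and it may stay within the scatter. For compound 4 the estimated value is 1300 nM, with an expected range of 300 nM to 6000 nM.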

Compound 4, half-maximal inhibitory concentration: > 50000 nM
Compound 4 ended at the assay's limit; the forecaster's own chance of this, stated with the estimate: 8%; middle value at least 38-fold (1.58 log units) from the limit.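

In this assay, the place opposite the ring nitrogen turns out to matter as well: with the hydroxyphenyl groups of compound 3 kept, pyridin-3-yl in place of thiophen-3-yl gives an at least 65-fold higher number from compound 3 to compound 4 (1.81 log units; beyond the scatter). The result for compound 4 is a limit and not a number, so the step has a lower bound but no known full size. The earlier compounds tied the read-out only to the hydroxyphenyl groups, whereas compound 4 shows that the pattern of compound 3 does not by itself give a measurable value, and the single number in the set now stands with thiophen-3-yl at this place, while the rest share one ceiling: the limit of > 50000 nM in this assay, at which 3 of the 4 values shown sit.

The compounds shown do not separate the change of ring size from the change of hetero atom, so it stays open whether a phenyl, furan-3-yl or thiophen-2-yl group at this place would keep a measurable value. As far as these compounds go, it also stays open whether pyridin-4-yl, or a ring carrying an amine or a carboxylic acid, would behave as pyridin-3-yl does.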